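Swapping one halogenated phenyl ring for another

The compounds below may be only part of what the source reports. "The series", "measured", "known", "first", "only" and "open" are said of these compounds alone.

Of the compounds shown here, two sharing a core have been measured in a physicochemical assay for lipophilicity, measured as octanol-water partition; a higher number here means a more lipophilic compound, a lower number a more polar compound. Compound 1, `O=C(COc1cccc2ccccc12)N/N=C/c1ccccc1Br`, gives 4.81 in this assay. Compound 2, `C/C(=N\NC(=O)COc1cccc2ccccc12)c1ccccc1O`, gives 3.08 in this assay. Compound 1 thus stands as the higher of the two numbers, with compound 2 a gap lower that lies beyond the usual scatter of repeated measurements.

Compound 3, `O=C(COc1cccc2ccccc12)N/N=C/c1cccc(Cl)c1`, has not yet been measured in this assay. It differs from compound 1 in one place: 3-chlorophenyl in place of 2-bromophenyl on a carbon with a double bond to nitrogen. Within the data shown here, no measured pair here isolates this kind of change, so the expectation rests on the change alone. The step of a number 0.21 log units lower from compound 1 to compound 3 (within the scatter) is expected to be small, if anything a slight lowering, and not clearly beyond the scatter. Compound 3 is therefore estimated at 4.6, with a likely range from 4.2 to 5.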

Compound 3, partition coefficient: 4.54
The estimate for compound 3 lay 0.06 log units above the measured number; the measured number falls inside the stated range.
By their numbers in this assay, from the lowest: compound 2; then compounds 3 and 1 (each within the scatter of the next).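

Placing 3-chlorophenyl in place of 2-bromophenyl on a carbon with a double bond to nitrogen gives a number 0.27 log units lower from compound 1 to compound 3 (within the scatter) in this assay, so at this position the two halogenated phenyl rings cannot be told apart in this assay. Among these compounds, this is the first single-place step, and it shows that this particular exchange of one halogenated ring for another leaves the two numbers within the spread of repeat measurements. The halogen and its place on the ring differ together in this swap, so the pair cannot separate the two, and no measurement at hand offers an explanation for the closeness of the numbers.

Still open, on these data alone, is how a phenyl ring carrying an amine or a carboxylic acid would compare with compound 1 at this place. Equally open, as far as these compounds go, is what a plain phenyl ring, with no halogen at all, would give.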